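A few compounds are considered here, and "the series" means these few. Any claim that something is new, unique, unknown or untested is made for them only; others in the source may bear on it.

Of the compounds shown here, three built on one shared core have so far been tested in a functional assay on MOLT-4 cells (Homo sapiens) for antiproliferative activity; on this read-out lower numbers stand for stronger inhibition and higher numbers for weaker inhibition. Compound 1 `COc1cc(C(=O)c2sc(-c3ccc(F)cc3)cc2N)cc(OC)c1OC` gives 12 nM. Compound 2 `CCOc1ccc(-c2cc(N)c(C(=O)c3cc(OC)c(OC)c(OC)c3)s2)cc1` gives 240 nM, and compound 3 `COc1cc(C(=O)c2sc(-c3ccc([N+](=O)[O-])cc3)cc2N)cc(OC)c1OC` gives 110 nM. On these numbers compound 3 stands second highest of the three, with compound 2 as its nearest neighbour and compound 1 as its furthest. Among the single-site changes, the ethoxy for fluoro exchange was the largest: a 20-fold higher number from compound 1 to compound 2 (1.30 log units; beyond the scatter).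

Compound 4 `COc1cc(C(=O)c2sc(-c3ccc(-c4ccccc4)cc3)cc2N)cc(OC)c1OC` differs from compound 3 in one place: phenyl in place of nitro on an aromatic carbon. For the measured compounds named here, two measured steps touch the same aromatic carbon and therefore bear on this change, a 9.2-fold higher number from compound 1 to compound 3 (0.96 log units; beyond the scatter) from fluoro and a 2.2-fold lower number from compound 2 to compound 3 (0.34 log units; beyond the scatter) from ethoxy, both modest in size. Neither step involves a phenyl group, so nothing measured shows directly what phenyl does at this position; the three groups compared so far give numbers spread across a modest to large range, with fluoro lowest. The account accordingly expects a step of modest size at most from compound 3 to compound 4, with no firm direction, expressed as a 1.8-fold higher number from compound 3 to compound 4 (0.26 log units; within the scatter). Compound 4 is estimated at 200 nM in this assay, within a range of 50 nM to 800 nM.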

Compound 4, half-maximal inhibitory concentration: > 10000 nM
Compound 4: no number, only a limit; the forecaster's own chance of this, stated with the estimate: 5%; middle value at least 50-fold (1.69 log units) away from the limit.
By their numbers in this assay, from the lowest: compound 1; then compound 3; then compound 2. At a limit, above all of these: compound 4.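

In this assay, compound 4 is recorded only as a limit of the assay and not as a number: the limit of > 10000 nM in this assay, at which 1 of the 4 values shown sits. Read against that limit, phenyl stands apart from all three earlier groups, with an at least 90-fold higher number from compound 3 to compound 4 (1.95 log units; beyond the scatter) from nitro, an at least 41-fold higher number from compound 2 to compound 4 (1.61 log units; beyond the scatter) from ethoxy and an at least 830-fold higher number from compound 1 to compound 4 (2.92 log units; beyond the scatter) from fluoro, and each of these steps is large and beyond the scatter. For the compounds shown here, the earlier compounds showed that this aromatic carbon moves the number while keeping it measurable; compound 4 shows that a change here can also carry the read-out to the limit of the assay, and phenyl is the only one of the four groups that brings a ring of its own.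

With a single ring-bearing compound, the compounds shown cannot separate the effect of the ring from that of the group's overall size, and a cyclopropyl ring, a pyridine ring or a longer chain such as butoxy at this carbon would bear on that question. They also leave open how far beyond the limit compound 4 truly lies, so the three steps give only lower bounds on the change.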